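A few compounds are considered here, and "the series" means these few. Any claim that something is new, unique, unknown or untested is made for them only; others in the source may bear on it.

Measured so far in an ADME assay on cells (Epithelial cell, Homo sapiens) for cytotoxicity, read by MTT assay; on this read-out higher numbers stand for an effect only at larger amounts of compound and lower numbers for an effect already at smaller amounts:
compound 1 `CCCCCCCCCCCCCCCCOC(=O)NC(CCC(=O)O)(CCC(=O)O)CCC(=O)O` gives 440000 nM;
compound 2 `CCCCCCCCCCCCCCCCCCOC(=O)NC(CCC(=O)O)(CCC(=O)O)CCC(=O)O` gives 350000 nM;
compound 3 `CCCCCCCCCCCCCCCCCCCCNC(=O)NC(CCC(=O)O)(CCC(=O)O)CCC(=O)O` gives 210000 nM.

Compound 1 and compound 2 share one core, and the step of a 1.3-fold higher number from compound 2 to compound 1 (0.10 log units; within the scatter) is hydrogen in place of ethyl on a saturated chain carbon, ten or more bonds along the chain from an oxygen next to a carbonyl group. Compound 3 has a different core; how the two cores differ is not broken down here. Compound 4 `CCCCCCCCCCCCCCCCCCNC(=O)NC(CCC(=O)O)(CCC(=O)O)CCC(=O)O` is still unmeasured, and it arises from compound 3 by the same kind of change (hydrogen in place of ethyl on a saturated chain carbon, ten or more bonds along the chain from an amide-type nitrogen), the place now being counted from an amide-type nitrogen rather than from an oxygen next to a carbonyl group. Because the earlier step of a 1.3-fold higher number from compound 2 to compound 1 (0.10 log units; within the scatter) stayed within the scatter, the step of a 1.3-fold higher number from compound 3 to compound 4 (0.11 log units; within the scatter) is expected to be of a similar, small size. Compound 4 is therefore estimated at 270000 nM, with a likely range from 150000 nM to 480000 nM.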

Compound 4, half-maximal effective concentration: 280000 nM
Compound 4: middle estimate off by 1.0-fold (0.02 log units), on the low side; the range from low to high includes it.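

In this assay, among these compounds, hydrogen in place of ethyl on a saturated chain carbon gives a 1.3-fold higher number from compound 3 to compound 4 (0.12 log units; within the scatter), and the change looks alike on the two cores when the two steps are set side by side: the same change on two cores in this assay, a 1.3-fold higher number (0.10 log units; within the scatter) from compound 2 to compound 1 and a 1.3-fold higher number (0.12 log units; within the scatter) from compound 3 to compound 4, 1.1-fold (0.03 log units) apart, within the scatter of two such steps Both steps lie within the usual scatter, which means the pair shows only that the change stays small on both cores, not that it has a real effect of a fixed size. Two cores are also too few to show how the change would carry to any other core in this series.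

The compounds shown leave open what a much shorter chain, such as octyl, or an ester in place of the carboxylic acids would do in this assay. They also leave open how the change reads in any other test.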